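The compounds below may be only part of what the source reports. "The series", "measured", "known", "first", "only" and "open" are said of these compounds alone.

Compound 1 `CCCn1nc(-c2cccnc2)c2ccccc2c1=O` gives 86% in an assay on isolated protein (Oryctolagus cuniculus) with Thromboxane-A synthase (Homo sapiens) as the target, tested at 1 uM; a lower number here means less inhibition, a higher number more inhibition at the concentration tested (going by the name of the read-out). Compound 2 `O=C(O)CCCn1nc(-c2cccnc2)c2ccccc2c1=O` gives 73% in this assay.

Going by the values given here, compound 2 stands lowest of the two measured numbers; its only neighbour, compound 1, sits higher, and the step of a number 13 percentage points lower from compound 1 to compound 2 (beyond the scatter) is beyond the scatter. Compound 3 `O=C(O)c1ccc(Cn2nc(-c3cccnc3)c3ccccc3c2=O)cc1` differs from compound 2 in one place: 4-carboxyphenyl in place of 2-carboxyethyl on a saturated chain carbon bound to an aromatic nitrogen. Among the compounds with values here, only one measured step bears on this change, a number 13 percentage points lower from compound 1 to compound 2 (beyond the scatter), and it concerns the arrival of the carboxy group itself rather than a chain exchanged for a ring; after that step compound 2 still gives 73%. Within the data shown here, no measured step compares a 2-carboxyethyl against a 4-carboxyphenyl, so the size of the change is largely unknown. A step of a number 1 percentage points lower from compound 2 to compound 3 (within the scatter) is therefore expected, not beyond the scatter in either direction. Compound 3 is estimated at 72% in this assay, with a range from 50% to 90%.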

Compound 3, a percentage reported as inhibition, at one concentration (the size of the read-out at that concentration, not a potency): 64%
Beside the measured number, compound 3's estimate is 8 percentage points above it; low and high end bracket the measured number.
By their numbers in this assay, from the lowest: compounds 3 and 2 (each within the scatter of the next); then compound 1.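

In this assay, the step from the chain acid to the ring acid is a number 9 percentage points lower from compound 2 to compound 3 (within the scatter), so 2-carboxyethyl and 4-carboxyphenyl cannot be told apart at this position, even though the entering group brings a six-membered aromatic ring and more heavy atoms. Set against the uncharged, acid-free side chain of compound 1, the same group gives a number 22 percentage points lower from compound 1 to compound 3 (beyond the scatter), a modest step. At this position on a saturated chain carbon bound to an aromatic nitrogen, then, the carboxy group can be carried by a ring as well as by a chain, with readings that stay within the scatter of each other.

Still open, on these data alone, is how a phenyl ring without the carboxy group, or one bearing an amine in its place, would read here. No measurement at hand explains why any of these numbers fall where they do.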